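A few compounds are considered here, and "the series" means these few. Any claim that something is new, unique, unknown or untested is made for them only; others in the source may bear on it.

Two compounds share one core and differ only in the group attached to a nitrogen on an aromatic ring. Compound 1 `CC(C)c1ccc(-c2nc(SCc3cn(CC(=O)NC(=O)Nc4ccccn4)nn3)nc(Nc3ccccc3Cl)c2C#N)cc1` carries 2-chlorophenyl there, and compound 2 `CC(C)c1ccc(-c2nc(SCc3cn(CC(=O)NC(=O)Nc4ccccn4)nn3)nc(Nc3cccc(Cl)c3)c2C#N)cc1` carries 3-chlorophenyl. In a functional assay on ECa-109 cells (Homo sapiens) for inhibition, read by MTT assay, with a stated time of 72 h (a lower number here means a stronger inhibitor, a higher number a weaker inhibitor), compound 1 gives 23400 nM, and in this assay compound 2 gives 13300 nM. Among the measured compounds shown here, the only measured step, a 1.8-fold lower number from compound 1 to compound 2 (0.25 log units; within the scatter), lies within the scatter, so compound 2 and compound 1 cannot be told apart on these numbers. Compound 3 `CC(C)c1ccc(-c2nc(SCc3cn(CC(=O)NC(=O)Nc4ccccn4)nn3)nc(Nc3ccccc3)c2C#N)cc1` removes the chlorine altogether: hydrogen in place of chloro on an aromatic carbon, on an aromatic carbon of a six-membered aromatic ring of carbon only, meta to a large group. No measured step removes a chloro group; the single step shown only moves it, and that barely moved the number. The expected change is therefore small, a 1.4-fold higher number from compound 2 to compound 3 (0.13 log units; within the scatter), in no clear direction. Compound 3 is estimated at 18000 nM, with a range from 8000 nM to 40000 nM.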

Compound 3, half-maximal inhibitory concentration: > 64000 nM
Compound 3 was reported as a limit; the forecaster's own chance of this, stated with the estimate: 5%; at least 3.5-fold (0.55 log units) between middle value and limit.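

Until now the chlorine had only been moved between 2-chlorophenyl and 3-chlorophenyl, a step that stayed within the scatter, so nothing showed whether it mattered at all. In this assay, going to plain phenyl gives an at least 4.8-fold higher number from compound 2 to compound 3 (0.68 log units; beyond the scatter) and an at least 2.7-fold higher number from compound 1 to compound 3 (0.43 log units; beyond the scatter), both beyond the scatter, so across these three compounds having a chlorine on this ring counts for more than which of the two places it holds. The value of compound 3 is a limit and not a number, so the true size of both steps stays unknown: the limit of > 64000 nM in this assay, at which 1 of the 3 values shown sits.

The compounds shown leave open whether chlorine itself is needed, or whether a fluoro, methyl or methoxy group in its place would serve as well. They also do not tell how 4-chlorophenyl would compare, or whether a second chlorine on the ring would give a stronger inhibitor.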